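Working notes: from compound 1 to compound 4

This account rests on a few compounds, and the source may have more. Where it says the series, first, only, none or still open, it means among the compounds named here.

- compound 1 `COc1ccc(CN(C(=O)CSc2nc3ccccc3s2)c2cc(OC)c(OC)c(OC)c2)cc1N=[N+]=[N-]`: 14400 nM
- compound 2 `COc1ccc(CN(C(=O)CSc2nc3ccccc3s2)c2cc(OC)c(OC)c(OC)c2)cc1`: 8460 nM
- compound 3 `COc1ccc(CN(C(=O)CSc2nc3ccccc3s2)c2cc(OC)c(OC)c(OC)c2)cc1O`: 2110 nM

In a functional assay on PC-3 cells (Homo sapiens) for antiproliferative activity, read by MTT assay, with a stated time of 48 h (on this read-out higher numbers stand for weaker inhibition and lower numbers for stronger inhibition), compound 1 gives 14400 nM, which places it at the upper end of the measured range, a position shared with compound 2. Its nearest neighbour lies at a 1.7-fold lower number from compound 1 to compound 2 (0.23 log units; within the scatter), and its furthest at a 6.8-fold lower number from compound 1 to compound 3 (0.83 log units; beyond the scatter).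

Compound 4 `COc1cc(CN(C(=O)CSc2nc3ccccc3s2)c2cc(OC)c(OC)c(OC)c2)cc(OC)c1OC` has not yet been measured. It carries 3,4,5-trimethoxyphenyl in place of 3-azido-4-methoxyphenyl on a saturated chain carbon bound to an amide-type nitrogen.

Among the measured compounds shown here, no measured step introduces the 3,4,5-trimethoxyphenyl group, so the evidence is indirect. Losing the azido group without a replacement gave a 1.7-fold lower number from compound 1 to compound 2 (0.23 log units; within the scatter), which suggests that compound 2 is the closest guide. The only clear gains came with hydroxy, in a 6.8-fold lower number from compound 1 to compound 3 (0.83 log units; beyond the scatter) and a 4.0-fold lower number from compound 2 to compound 3 (0.60 log units; beyond the scatter), and compound 4 has no hydroxy group. A small step towards a lower number is therefore expected in this assay, smaller than the step to compound 3, and it may not clear the scatter.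

The estimated step is a 1.9-fold lower number from compound 1 to compound 4 (0.28 log units; within the scatter).

For compound 4 the estimated value is 7500 nM, with an expected range of 2500 nM to 20000 nM.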

Compound 4, half-maximal inhibitory concentration: > 80000 nM
Compound 4: a limit, no number (the forecaster's own chance of this, stated with the estimate: 3%); at least 10-fold (1.02 log units) between middle value and limit.
By their numbers in this assay, from the lowest: compound 3; then compounds 2 and 1 (each within the scatter of the next). At a limit, above all of these: compound 4.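

In this assay compound 4 is known only as a limit, not as a number: the limit of > 80000 nM in this assay, at which 1 of the 4 values shown sits.

Every step into the 3,4,5-trimethoxyphenyl group, on a saturated chain carbon bound to an amide-type nitrogen, runs the same way and lies beyond the scatter: an at least 5.5-fold higher number from compound 1 to compound 4 (0.74 log units; beyond the scatter), an at least 9.4-fold higher number from compound 2 to compound 4 (0.97 log units; beyond the scatter) and an at least 37-fold higher number from compound 3 to compound 4 (1.57 log units; beyond the scatter). The earlier compounds shown here showed this aryl group only as a site of shifts that were modest or within the scatter, whereas compound 4 shows that a change here can end at the limit of the assay rather than at a number.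

The compounds shown leave open whether a single added methoxy group on the 4-methoxyphenyl of compound 2 would already carry much of this step, or whether it takes the full 3,4,5-trimethoxyphenyl pattern. Also open, on these data alone, is whether the lower number seen with the 3-hydroxy-4-methoxyphenyl group of compound 3 would hold with an amine or a carboxylic acid in place of that hydroxy.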